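The source may hold more compounds than are shown below. What is called first, only, known or untested is meant among the compounds shown, and "the series" means these compounds.

In a functional assay on Jurkat cells (Homo sapiens) for inhibition, read by CCK-8 assay, with a stated time of 48 h (on this read-out lower numbers stand for stronger inhibition of growth and higher numbers for weaker inhibition of growth), compound 1 (`Cc1ccccc1Nc1nc(NC2CCCCC2)ncc1Cl`) gives > 100000 nM, which is a limit of the assay. Compound 2 (`Cc1ccccc1Nc1nc(Nc2ccccc2)ncc1Cl`) gives > 100000 nM, also a limit. Compound 3 (`Cc1ccccc1Nc1nc(NCc2ccncc2)ncc1Cl`) gives > 100000 nM, again a limit. Compound 2 thus stands at the limit of > 100000 nM in this assay, at which 3 of the 3 values shown sit. Compound 4 (`CCN1CCN(c2ccc(Nc3ncc(Cl)c(Nc4ccccc4C)n3)cc2)CC1`) departs from it by 4-ethylpiperazin-1-yl in place of hydrogen on an aromatic carbon. The measured steps, a step that the two limits leave unreadable from compound 1 to compound 2, a step that the two limits leave unreadable from compound 1 to compound 3 and a step that the two limits leave unreadable from compound 2 to compound 3, all exchange the group on a nitrogen, and none has a readable size to carry over. A step toward stronger inhibition of growth is nonetheless expected in this assay, though this rests on the structural change alone and its size is very uncertain. The estimated step is an at least 20-fold lower number from compound 2 to compound 4 (1.30 log units; beyond the scatter). For compound 4 the estimated value is 5000 nM, with an expected range of 500 nM to 50000 nM.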

Compound 4, concentration for 50% growth inhibition: 2060 nM
Estimate against measurement, compound 4: 2.4-fold (0.39 log units) above; low and high end bracket the measured number.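

In this assay, for the compounds shown here, 4-ethylpiperazin-1-yl in place of hydrogen on an aromatic carbon, para to a large group, gives the first step of readable size (an at least 48-fold lower number from compound 2 to compound 4 (1.68 log units; beyond the scatter)). The earlier exchanges of the group on the nitrogen cannot be read, and compound 4 is the only compound shown that leaves the limit: the limit of > 100000 nM in this assay, at which 3 of the 4 values shown sit.

The compounds shown leave open which part of the 4-ethylpiperazin-1-yl group carries this step. They also leave open whether a morpholine, a piperazine without the ethyl group or a dimethylamino group at the same place would give a similar step.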